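Allyloxy to Benzyloxy on a Shared Core: Expectation at the Limit

This account rests on a few compounds, and the source may have more. Where it says the series, first, only, none or still open, it means among the compounds named here.

Of the compounds shown here, three with the same core have been measured in a functional assay on U-266 cells (Homo sapiens) for cytotoxicity, read by colorimetric assay, with a stated time of 72 h; on this read-out lower numbers stand for stronger inhibition and higher numbers for weaker inhibition. Compound 1, `OC[C@H](NC[C@H]1NC[C@H](O)[C@@H]1O)c1ccc(-c2ccccc2)cc1`, reaches only a limit of the assay in this assay, > 200000 nM. Compound 2, `OC[C@H](NC[C@H]1NC[C@H](O)[C@@H]1O)c1ccc(-c2ccsc2)cc1`, is recorded in this assay as "not active" (no number reported), with no number given. Compound 3, `C=CCOc1ccc([C@H](CO)NC[C@H]2NC[C@H](O)[C@@H]2O)cc1`, likewise stops at a limit of the assay in this assay, > 200000 nM. The step that the two limits leave unreadable from compound 1 to compound 3 therefore has no readable size, and compound 3 cannot be ranked against compound 1 or compound 2; it simply stands at the limit together with them.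

Compound 4, `OC[C@H](NC[C@H]1NC[C@H](O)[C@@H]1O)c1ccc(OCc2ccccc2)cc1`, differs from compound 3 by phenyl in place of vinyl on a saturated chain carbon bound to an oxygen on an aromatic ring. Among the compounds with values here, no measured step covers this change, and the only evidence on the numbers is the limit of > 200000 nM in this assay, at which 2 of the 3 values shown sit. Within the data shown here, nothing among the measured compounds points away from the limit. The expected step is a number no higher from compound 3 to compound 4 (the limit leaves the size open), not readable beyond the scatter. Compound 4 is accordingly estimated at 200000 nM, within 60000 nM to 600000 nM, and most probably reported again only as a limit.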

Compound 4, half-maximal inhibitory concentration: "not active" (no number reported)
Nothing numeric was reported for compound 4; the estimate stays without a comparison.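

In this assay compound 4 gives "not active" (no number reported), so no step can be read between compound 3 and compound 4. The compounds shown leave open whether any change to the shared core would give a readable number in this assay.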